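Two Pyridyl Guanidines and a Dichlorophenyl Successor

The source may report more compounds than this note shows. Statements on the series, on what has been measured and on what is new or still open speak of the compounds shown alone.

Compound 1, `N=C(NCCCc1c[nH]cn1)NCCC(c1cccc(F)c1)c1ccccn1`, and compound 2, `N=C(NCCCc1c[nH]cn1)NCCC(c1cccc(C(F)(F)F)c1)c1ccccn1`, share one core and differ only in the group on the phenyl ring. In a functional assay on cardiac atrium for agonist activity at histamine H2 receptor (Cavia porcellus) (a higher number here means a more potent compound, by a factor of ten per unit of this negative logarithm, a lower number a less potent compound), compound 1 gives 7.88, and in this assay compound 2 gives 7.43. Going by the values given here, the one step between them, a number 0.45 log units lower from compound 1 to compound 2 (beyond the scatter), is the only comparison available, so compound 2 stands as the lower of the two numbers.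

Compound 3, `N=C(NCCCc1c[nH]cn1)NCCC(c1ccc(Cl)c(Cl)c1)c1ccccn1`, is reached from compound 2 by the change (3,4-dichlorophenyl in place of 3-(trifluoromethyl)phenyl on a saturated chain carbon bound to an aromatic carbon and a saturated chain carbon). Among the compounds with values here, no measured step covers an exchange of this kind, since the only step known swaps one small group for another on the same ring position, and it reached only a modest size. That step gives no direct guide for two chlorines at new places, so the step from compound 2 to compound 3 in this assay is expected to be small, in either direction, and possibly within the scatter. On this basis compound 3 is expected to give about 7.5, within a range from 6.9 to 8.1. The corresponding step, a number 0.07 log units higher from compound 2 to compound 3 (within the scatter), is thus the estimated outcome.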

Compound 3, negative logarithm of the half-maximal effective concentration: 8.19
Estimate against measurement, compound 3: 0.69 log units below; measured number above the stated range.
By their numbers in this assay, from the lowest: compound 2; then compound 1; then compound 3.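

In this assay, the place on a saturated chain carbon bound to an aromatic carbon and a saturated chain carbon proves able to give more than the first pair showed: 3,4-dichlorophenyl in place of 3-(trifluoromethyl)phenyl brings a number 0.76 log units higher from compound 2 to compound 3 (beyond the scatter) and 3,4-dichlorophenyl in place of 3-fluorophenyl brings a number 0.31 log units higher from compound 1 to compound 3 (beyond the scatter) as well. Going by these compounds alone, the only earlier step on this ring went downward, so the new result is the first to show that changing this aryl group can raise the number, and it puts compound 3 highest of the three. No measurement shown explains why 3,4-dichlorophenyl stands above the two other groups.

Since the two chlorines enter together, these compounds cannot tell whether a phenyl ring with a single chlorine would do as well or whether both are needed. From the compounds shown here alone, how a phenyl ring carrying a methoxy group, an amine or a carboxylic acid would behave at this place also remains open, as does whether the gain would hold in any assay other than this one.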